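The source may hold more compounds than are shown below. What is called first, only, known or untested is meant among the compounds shown, and "the series" means these compounds.

In an ADME assay on MCF7 cells (Homo sapiens) for cytotoxicity (on this read-out higher numbers stand for weaker inhibition and lower numbers for stronger inhibition), compound 1 `Oc1cc2cc(c1)Oc1c(O)cc(cc1O)[C@H](O)CCCCCC/C=C/CCCCC2` gives 30000 nM and compound 2 `COc1cc(O)cc(CCCCCCCCCCCCCCc2cc(O)cc(O)c2)c1` gives 29400 nM, so these two numbers lie within the usual scatter of each other. Compound 3 `Oc1cc2cc(c1)Oc1c(O)cc(cc1O)CCCCCCC/C=C/CCCCC2` keeps the core of compound 1 with one change: hydrogen in place of hydroxy on a saturated ring carbon. For the measured compounds named here, no measured pair shows the effect of such a change in this assay, so only a small shift toward stronger inhibition is expected, possibly none beyond the scatter. The expected step is a 1.2-fold lower number from compound 1 to compound 3 (0.08 log units; within the scatter). For compound 3, the estimated value is 25000 nM, with an expected range of 10000 nM to 60000 nM.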

Compound 3, half-maximal inhibitory concentration: 31800 nM
Compound 3: the middle estimate sits 1.3-fold (0.10 log units) below what was measured; the range from low to high includes it.
By their numbers in this assay, from the lowest: compounds 2, 1 and 3 (each within the scatter of the next).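

In this assay the change to hydrogen in place of hydroxy on a saturated ring carbon gives a 1.1-fold higher number from compound 1 to compound 3 (0.03 log units; within the scatter) and so stays within the scatter. This single pair therefore shows no measurable role for this hydroxy group in this read-out, at this position on the shared core. Nothing available offers an explanation for this result. As far as these compounds go, whether an amine or a carboxylic acid on the same ring carbon would also leave the number in place remains open. A single pair also cannot say whether removing a hydroxy group elsewhere on the core would do the same.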